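Methyl on an aromatic nitrogen: three limits, one gap

This account rests on a few compounds, and the source may have more. Where it says the series, first, only, none or still open, it means among the compounds named here.

Measured so far:
Compound 1 `Clc1ccc(-c2noc(-c3cc4cc(Cl)ccc4[nH]3)n2)cc1`; in a functional assay on MIA PaCa-2 cells (Homo sapiens) for antiproliferative activity, read by WST assay, with a stated time of 72 h (a higher number here means a weaker inhibitor, a lower number a stronger inhibitor), compound 1 gives > 50000 nM, which is a limit of the assay rather than a number.
Compound 2 `Cn1c(-c2nc(-c3ccc(Cl)cc3)no2)cc2cc(Cl)ccc21`; in this assay compound 2 gives > 50000 nM, also a limit.
Compound 3 `COc1ccc(-c2noc(-c3cc4ccccc4[nH]3)n2)cc1`; in this assay compound 3 gives > 50000 nM, again a limit.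

Compound 1 and compound 2 differ by methyl in place of hydrogen on an aromatic nitrogen. The step that the two limits leave unreadable from compound 1 to compound 2 cannot be sized because of the limit of > 50000 nM in this assay, at which 3 of the 3 values shown sit, so whether the methyl helps or hurts is not readable from this pair. Compound 3 shares the general build of compound 1 but the difference between the two cores is not broken down here.

Compound 4 `COc1ccc(-c2noc(-c3cc4ccccc4n3C)n2)cc1` is not yet measured. Going by the values given here, it differs from compound 3 by methyl in place of hydrogen on an aromatic nitrogen, the same change as the one between compound 1 and compound 2. Given that both members of that pair sit at the limit, the step from compound 3 to compound 4 is expected to be a step that the limit leaves unreadable from compound 3 to compound 4, with the pair of compound 1 and compound 2 as the only guide. Compound 4 is therefore expected to give 70000 nM in this assay, most likely reported again as a limit, within a range of 20000 nM to 250000 nM.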

Compound 4, half-maximal inhibitory concentration: 23100 nM
The estimate for compound 4 lay 3.0-fold (0.48 log units) above the measured number; low and high end bracket the measured number.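

Going by these compounds alone, on the core of compound 3, methyl in place of hydrogen on an aromatic nitrogen gives an at least 2.1-fold lower number from compound 3 to compound 4 (0.33 log units; beyond the scatter) in this assay, and compound 4 is the only compound here with a measured number rather than a limit. The same change on the core of compound 1 cannot be read, because compound 1 and compound 2 both stand at the limit: the limit of > 50000 nM in this assay, at which 3 of the 4 values shown sit. The step therefore shows that the methyl lowers the number on one core, but it neither confirms nor contradicts a transfer to the other core, and compound 2, which carries the same methyl, yields no number.

Still open, going by these compounds, is whether a longer chain on that same nitrogen, such as ethyl or propyl, or a chain ending in an amine or a carboxylic acid, would extend the step seen for compound 4 or lose it. Also open, on these data alone, is how the chloro and methoxy substituted cores compare, since compound 1 and compound 3 differ in more than one place.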